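Extending the oxadiazole substituent from methyl to aryl

A few compounds are considered here, and "the series" means these few. Any claim that something is new, unique, unknown or untested is made for them only; others in the source may bear on it.

Compound 1, `COc1ccc2[nH]c(-c3nc(C)no3)cc2c1`, 10400 nM.
Compound 2, `Cc1noc(-c2cc3cc(F)ccc3[nH]2)n1`, 18100 nM.

In a functional assay on COLO 320 cells (Homo sapiens) for antiproliferative activity, read by WST assay, with a stated time of 72 h (on this read-out higher numbers stand for weaker inhibition and lower numbers for stronger inhibition), compound 1 gives 10400 nM, and compound 2 sits alongside it: a 1.7-fold higher number from compound 1 to compound 2 (0.24 log units; within the scatter). Compound 3, `COc1ccc(-c2noc(-c3cc4cc(OC)ccc4[nH]3)n2)cc1`, carries the shared core of compound 1 with one change: 4-methoxyphenyl in place of methyl on an aromatic carbon. Going by the values given here, the only measured step, from compound 1 to compound 2, alters the indole substituent and says nothing about the oxadiazole substituent. Among the compounds with values here, no measured step therefore bears on this change, and the direction of this assay is open. Compound 3 is estimated at 8000 nM, within 1500 nM to 40000 nM, an expected step of a 1.3-fold lower number from compound 1 to compound 3 (0.11 log units; within the scatter).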

Compound 3, half-maximal inhibitory concentration: 28300 nM
Compound 3: the middle estimate sits 3.5-fold (0.55 log units) below what was measured, and the stated range covers the measured number.
By their numbers in this assay, from the lowest: compounds 1, 2 and 3 (each within the scatter of the next, the first and the last beyond it).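

Placing 4-methoxyphenyl instead of methyl on the aromatic carbon between two ring nitrogen atoms gives the first reading at this position: in this assay there is a 2.7-fold higher number from compound 1 to compound 3 (0.43 log units; beyond the scatter) and so inhibition weakens modestly with the larger group. Nothing measured here explains this shift.
From the compounds shown here alone, whether plain phenyl, an ethyl group or an amine on this carbon would give a number closer to that of compound 1 stays open. So does whether the same change would have a similar effect on the core of compound 2.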